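The compounds below may be only part of what the source reports. "The series", "measured", "known", "first", "only" and "open" are said of these compounds alone.

- Compound 1 `CN(Cc1ccc(Cl)cc1)Cc1ccc(CNc2ccnc3cc(Cl)ccc23)cc1` measures 9.74
- Compound 2 `CN(Cc1ccccc1)Cc1ccc(CNc2ccnc3cc(Cl)ccc23)cc1` measures 9.9

In a physicochemical assay for acid dissociation, compound 2 stands at 9.9, within the usual scatter of compound 1 at 9.74. Compound 3 `COc1ccc(CN(C)Cc2ccc(CNc3ccnc4cc(Cl)ccc34)cc2)cc1` is still unmeasured and carries methoxy in place of hydrogen on an aromatic carbon, methoxy in place of hydrogen on an aromatic carbon. Among the measured compounds shown here, the one measured step that bears on this is a number 0.16 log units higher from compound 1 to compound 2 (within the scatter), with hydrogen in place of chloro on an aromatic carbon. For the measured compounds named here, no compound measured so far carries methoxy, so this single step is only a rough guide. In this assay the expected change is a number 0.05 log units higher from compound 2 to compound 3 (within the scatter), no step beyond the scatter. Compound 3 is estimated at 9.95, with an expected range of 9.6 to 10.25.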

Compound 3, acid dissociation constant: 9.7
The estimate for compound 3 lay 0.25 log units above the measured number; the measured number falls inside the stated range.
By their numbers in this assay, from the lowest: compounds 3, 1 and 2 (each within the scatter of the next).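

In this assay, the step reads a number 0.20 log units lower from compound 2 to compound 3 (within the scatter) for methoxy in place of hydrogen and a number 0.04 log units lower from compound 1 to compound 3 (within the scatter) for methoxy in place of chloro. Hydrogen, chloro and methoxy on this aromatic carbon, para to a large group, therefore all give numbers within the scatter of one another. Nothing available explains why these numbers stay so close. As far as these compounds go, whether an amine, a carboxylic acid or a longer chain at this position would give a step beyond the scatter remains open.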